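Morpholine Carbonyl in Place of Methylcarbamoyl

The compounds below may be only part of what the source reports. "The series", "measured", "known", "first", "only" and "open" are said of these compounds alone.

Compound 1 `O=C(NO)[C@H]1CNCCN1S(=O)(=O)N1CC=C(c2ccc(F)cc2)CC1` gives 3560 nM in a functional assay on MONO-MAC-6 cells (Homo sapiens) for inhibition; a higher number here means a weaker inhibitor, a lower number a stronger inhibitor. For the measured compounds named here, compound 2 `CNC(=O)N1CCN(S(=O)(=O)N2CC=C(c3ccc(F)cc3)CC2)[C@@H](C(=O)NO)C1` gives 120 nM, the lower of the two numbers; the only measured step, a 30-fold lower number from compound 1 to compound 2 (1.47 log units; beyond the scatter), is large. Compound 3 `O=C(NO)[C@H]1CN(C(=O)N2CCOCC2)CCN1S(=O)(=O)N1CC=C(c2ccc(F)cc2)CC1` differs from compound 2 by morpholin-4-yl in place of methylamino on a carbonyl carbon. Going by the values given here, no measured step covers this change: the step from compound 1 to compound 2 concerns adding the carbamoyl group, not exchanging the part attached to its carbonyl carbon, so it gives little guidance on direction. The expected step is therefore small, a 1.3-fold higher number from compound 2 to compound 3 (0.10 log units; within the scatter), perhaps within the scatter. Compound 3 is estimated at 150 nM, in the range 50 nM to 450 nM.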

Compound 3, half-maximal inhibitory concentration: 350 nM
The estimate for compound 3 lay 2.3-fold (0.37 log units) below the measured number; the range from low to high includes it.
By their numbers in this assay, from the lowest: compound 2; then compound 3; then compound 1.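

In this assay, the group on the carbonyl carbon matters: exchanging methylamino for morpholin-4-yl costs potency (a 2.9-fold higher number from compound 2 to compound 3 (0.46 log units; beyond the scatter)). Even so, (morpholin-4-yl)carbonyl keeps most of the gain over hydrogen on the amine nitrogen in a ring (a 10-fold lower number from compound 1 to compound 3 (1.01 log units; beyond the scatter)), so this gain does not depend on methylamino alone. Nothing measured here explains the difference between the two groups. As far as these compounds go, it remains open whether the ring itself or the loss of the amine hydrogen drives the step. Dimethylamino or piperidin-1-yl on the same carbonyl carbon would help separate these.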